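Swapping cyano for fluoro in a mouse tail assay

The source may report more compounds than this note shows. Statements on the series, on what has been measured and on what is new or still open speak of the compounds shown alone.

- compound 1 `N#Cc1ccc(-c2ccc(/C=N/N3C(=O)NC(=O)C3O)o2)cc1`: 743 mg/kg
- compound 2 `CC(=O)Nc1ccc(-c2ccc(/C=N/N3C(=O)NC(=O)C3O)o2)cc1`: > 1000 mg/kg (a limit)
- compound 3 `O=C1CN(/N=C/c2ccc(-c3cccc(C(F)(F)F)c3)o2)C(=O)N1`: 184 mg/kg

In a functional assay on the whole organism (Tail) for activation, with Mus musculus as the target, with a stated time of 1 min (a lower number here means that less compound is needed, a higher number that more compound is needed for the effect), compound 1 gives 743 mg/kg, the higher of the two actual numbers, and compound 3 gives 184 mg/kg, a lower number beyond the scatter. The result for compound 2 is a limit, not a number: > 1000 mg/kg.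

Compound 4 `O=C1NC(=O)N(/N=C/c2ccc(-c3ccc(F)cc3)o2)C1O` has not yet been measured. It differs from compound 1 by fluoro in place of cyano on an aromatic carbon, para to a large group (fluoro in place of cyano on an aromatic carbon). Going by the values given here, the one measured step at this place is an at least 1.3-fold higher number from compound 1 to compound 2 (0.12 log units; that floor lies within the scatter), and it gives only a floor. With no larger step shown there, no change beyond the scatter is expected in this assay.

The expected change is a 1.2-fold lower number from compound 1 to compound 4 (0.09 log units; within the scatter). For compound 4 the estimated value is 600 mg/kg, with an expected range from 250 mg/kg to 1300 mg/kg.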

Compound 4, dose for half-maximal effect: > 1000 mg/kg
Compound 4 gave a limit, no number (the forecaster's own chance of this, stated with the estimate: 20%); middle value at least 1.6-fold (0.22 log units) away from the limit.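

Fluoro in place of cyano gives an at least 1.3-fold higher number from compound 1 to compound 4 (0.12 log units; that floor lies within the scatter), and since this is only a floor, the true size of the step stays open upward. In this assay, the result for compound 4 is a limit, as is the result for compound 2, so of the three groups shown at this place only cyano, in compound 1, gives a readable number. The step between the two limited compounds cannot be read, and the top of the measured range now governs what can be said about this position: the limit of > 1000 mg/kg in this assay, at which 2 of the 4 values shown sit.

Going by these compounds, how far compound 2 and compound 4 lie beyond that limit remains open. So does whether an amine or a carboxylic acid at this place, on the core of compound 1, would give a readable number in this assay.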